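The source may report more compounds than this note shows. Statements on the series, on what has been measured and on what is new or still open speak of the compounds shown alone.

Compound 2, whose structure is `CC(C)(C)C(=O)N1CCC(NCC[S+]([O-])C(c2ccc(F)cc2)c2ccc(F)cc2)CC1`, gives 10200 nM in an assay on membranes from striatum (strain Sprague-Dawley) for displacement of a labelled ligand from sodium-dependent dopamine transporter (Rattus norvegicus), read by scintillation counting, with a stated time of 120 min; a lower number here means a stronger inhibitor, a higher number a weaker inhibitor. Among the two compounds measured in this assay it sits at the highest number, and its nearest neighbour is compound 1, `O=C(c1ccc(F)cc1)N1CCC(NCC[S+]([O-])C(c2ccc(F)cc2)c2ccc(F)cc2)CC1`, which gives 77.2 nM in this assay. Among the measured compounds shown here, the one measured step that joins these two is a 130-fold higher number from compound 1 to compound 2 (2.12 log units; beyond the scatter), so putting an aromatic ring back on the carbonyl carbon in place of the saturated group is the change that has already been seen to matter most here.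

Compound 3, `O=C(c1ccc(F)cc1F)N1CCC(NCC[S+]([O-])C(c2ccc(F)cc2)c2ccc(F)cc2)CC1`, is the next compound to be measured. It differs from compound 2 in one place: 2,4-difluorophenyl in place of tert-butyl on a carbonyl carbon. This change retraces the measured step from compound 2 back toward compound 1, with one extra fluorine on the entering ring, and the step from compound 1 to compound 2 was large. The expectation for compound 3 is therefore a large step to a lower number in this assay, of about a 100-fold lower number from compound 2 to compound 3 (2.01 log units; beyond the scatter). On that basis compound 3 is estimated at 100 nM, within a range from 30 nM to 400 nM.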

Compound 3, inhibition constant: 564 nM
Compound 3: middle estimate off by 5.6-fold (0.75 log units), on the low side, outside the stated range (above it).
By their numbers in this assay, from the lowest: compound 1; then compound 3; then compound 2.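

In this assay, an aromatic ring on the carbonyl carbon again gives a far lower number than tert-butyl, with an 18-fold lower number from compound 2 to compound 3 (1.26 log units; beyond the scatter), so the gain seen with compound 1 is not confined to the 4-fluorophenyl group. The gain does not carry over in full, however: fluoro in place of hydrogen on an aromatic carbon, which turns 4-fluorophenyl into 2,4-difluorophenyl, gives a 7.3-fold higher number from compound 1 to compound 3 (0.86 log units; beyond the scatter). This position therefore responds not only to the exchange of tert-butyl for an aromatic ring, but also to a single substitution on that ring, with both aromatic compounds still standing well below compound 2.

No evidence at hand explains why the added fluorine raises the number or why either aromatic group lowers it relative to tert-butyl. On these data alone, it remains open whether an unsubstituted phenyl or a pyridine ring on the carbonyl carbon would fall nearer compound 1 or compound 3, and whether a cyclohexyl group there would stay as high as compound 2.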